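The source may report more compounds than this note shows. Statements on the series, on what has been measured and on what is new or still open speak of the compounds shown alone.

Working notes on the sulfonamide series, read in an assay on isolated protein for inhibition of Rho-associated protein kinase 2 (Homo sapiens), read by scintillation counting, radiometric assay and 33P incorporation, with a stated time of 40 min, in the presence of a further agent that is not named here; a lower number here means a stronger inhibitor, a higher number a weaker inhibitor. Compound 1 `CN(C)c1ccc(S(=O)(=O)Nc2cccc(NC(=O)COc3ccc4c(=O)ccoc4c3)c2)cc1` gives 263 nM. Compound 2 `CC(C)(C)c1ccc(S(=O)(=O)Nc2cccc(NC(=O)COc3ccc4c(=O)ccoc4c3)c2)cc1` gives 899 nM, and compound 3 `O=C(COc1ccc2c(=O)ccoc2c1)Nc1cccc(NS(=O)(=O)c2ccc(C(F)(F)F)cc2)c1` gives 6890 nM, the highest number among the three measured compounds, with every step separating it from the others beyond the scatter. All three measured steps exchange the group on the aromatic carbon para to a large group: a 3.4-fold higher number from compound 1 to compound 2 (0.53 log units; beyond the scatter), a 26-fold higher number from compound 1 to compound 3 (1.42 log units; beyond the scatter), and a 7.7-fold higher number from compound 2 to compound 3 (0.88 log units; beyond the scatter). Compound 4 `O=C(COc1ccc2c(=O)ccoc2c1)Nc1cccc(NS(=O)(=O)c2ccc(OC(F)(F)F)cc2)c1` is not yet measured; it differs from compound 3 by trifluoromethoxy in place of trifluoromethyl on an aromatic carbon. Among the compounds with values here, no measured step exchanges one fluorine-bearing group for another, so the three steps bear on this change only indirectly: each exchange at this position moved this assay by a modest or large amount, so a shift beyond the scatter is possible, though its direction is not fixed by the data. Because compound 3 sits at 6890 nM, the change is expected to give a modestly lower number, as step a 1.7-fold lower number from compound 3 to compound 4 (0.24 log units; within the scatter). Compound 4 is accordingly estimated at 4000 nM, within a range from 1400 nM to 12000 nM.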

Compound 4, half-maximal inhibitory concentration: 1280 nM
Estimate against measurement, compound 4: 3.1-fold (0.49 log units) above; measured number outside the range, below it.
By their numbers in this assay, from the lowest: compound 1; then compounds 2 and 4 (each within the scatter of the next); then compound 3.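

Within the fluorine-bearing groups this position is not indifferent: in this assay, trifluoromethoxy in place of trifluoromethyl gives a 5.4-fold lower number from compound 3 to compound 4 (0.73 log units; beyond the scatter), so the two groups cannot be treated as equivalent here. Trifluoromethoxy in place of tert-butyl gives a 1.4-fold higher number from compound 2 to compound 4 (0.15 log units; within the scatter), which leaves these two groups unordered, while trifluoromethoxy in place of dimethylamino gives a 4.9-fold higher number from compound 1 to compound 4 (0.69 log units; beyond the scatter), so compound 1 keeps the lowest number of the four. Nothing available accounts for the gap between trifluoromethyl and trifluoromethoxy at this position.

The compounds shown leave open whether the lower number of compound 1 is particular to dimethylamino or extends to another amine, such as pyrrolidine or morpholine. They also leave open where a plain methoxy group would fall relative to trifluoromethoxy on the same aromatic carbon.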